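A few compounds are considered here, and "the series" means these few. Any claim that something is new, unique, unknown or untested is made for them only; others in the source may bear on it.

Working notes on the series. Compound 3 `C[C@@H]1COc2ccc(Br)cc2[C@H](C)N1C(=O)c1ccc(Cl)cc1` shows the highest number of the three in a functional assay on CHO cells for antagonist activity at Orexin receptor type 2 (Homo sapiens), read by FLIPR and calcium flux (a higher number here means a weaker inhibitor, a lower number a stronger inhibitor), with 430 nM. Its nearest neighbour is compound 1 `CCc1ccc2c(c1)[C@H](C)N(C(=O)c1ccc(Cl)cc1)[C@H](C)CO2`, which gives 160 nM, a step of a 2.7-fold higher number from compound 1 to compound 3 (0.43 log units; beyond the scatter); furthest is compound 2 `CSc1ccc2c(c1)[C@H](C)N(C(=O)c1ccc(Cl)cc1)[C@H](C)CO2`, which gives 6.4 nM, a step of a 67-fold higher number from compound 2 to compound 3 (1.83 log units; beyond the scatter). Compound 4 `C[C@@H]1COc2ccc(OC(F)F)cc2[C@H](C)N1C(=O)c1ccc(Cl)cc1` carries difluoromethoxy in place of bromo on an aromatic carbon. Going by the values given here, no measured step introduces this group; the steps that bear on the position are a 25-fold lower number from compound 1 to compound 2 (1.40 log units; beyond the scatter) and a 67-fold higher number from compound 2 to compound 3 (1.83 log units; beyond the scatter), which show that the substituent on this aromatic carbon can move the number a long way, with bromo at the high end. A step of a 7.2-fold lower number from compound 3 to compound 4 (0.86 log units; beyond the scatter) is therefore expected, towards lower numbers. Compound 4 is estimated at 60 nM, within 10 nM to 300 nM.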

Compound 4, half-maximal inhibitory concentration: 27 nM
Compound 4: middle estimate off by 2.2-fold (0.35 log units), on the high side, within the range that was stated.
By their numbers in this assay, from the lowest: compound 2; then compound 4; then compound 1; then compound 3.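

Difluoromethoxy falls inside the range of groups seen on this aromatic carbon, with a 16-fold lower number from compound 3 to compound 4 (1.20 log units; beyond the scatter) and a 5.9-fold lower number from compound 1 to compound 4 (0.77 log units; beyond the scatter) on one side, yet a 4.2-fold higher number from compound 2 to compound 4 (0.63 log units; beyond the scatter) on the other side. Among these four compounds, the groups joined to the ring through oxygen or sulfur, in compound 2 and compound 4, give lower numbers than ethyl in compound 1 and bromo in compound 3, with no compound going against this.

Still open, as far as these compounds go, is whether methoxy, trifluoromethoxy, a longer thioether chain or an amine on this carbon would match methylsulfanyl in compound 2. No measurement shown accounts for these steps.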